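Chain-extended isothiocyanate analogue in the shared core series

This account rests on a few compounds, and the source may have more. Where it says the series, first, only, none or still open, it means among the compounds named here.

Measured so far:
compound 1, `CN(C)C(=O)c1cc2cnc(Nc3ccc(C(=O)NCCCN=C=S)cc3)nc2n1C1CCCC1`: 91.2%
compound 2, `CN(C)C(=O)c1cc2cnc(Nc3ccc(C(=O)NCCCN=C=S)cc3F)nc2n1C1CCCC1`: 78.5%

In a functional assay on NCI-H1299 cells (Homo sapiens) for inhibition, read by CCK-8 assay, with a stated time of 72 h, tested at 10 uM (a lower number here means a weaker effect, a higher number a stronger effect of the compound at the concentration tested), compound 1 gives 91.2% and compound 2 gives 78.5%. Among the compounds with values here, the single measured step, fluoro in place of hydrogen on an aromatic carbon, runs a number 12.7 percentage points lower from compound 1 to compound 2 (beyond the scatter). Within the data shown here, compound 2 therefore stands lowest of the two numbers, with compound 1 as its only neighbour.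

Compound 3, `CN(C)C(=O)c1cc2cnc(Nc3ccc(C(=O)NCCCCCCCN=C=S)cc3F)nc2n1C1CCCC1`, keeps the fluoro substituent of compound 2 and differs from it only in the chain carrying the isothiocyanate: a group of 7 heavy atoms (5 carbon, 1 nitrogen, 1 sulfur; no ring) in place of a group of 3 heavy atoms (1 carbon, 1 nitrogen, 1 sulfur; no ring), on a saturated chain carbon, three bonds along the chain from an amide-type nitrogen

Among the measured compounds shown here, no measured step concerns this chain, so the fluoro step gives no direct guide; it only shows that a single change can move the read-out beyond the scatter. With nothing in the numbers pointing either way, the chain extension is taken as roughly neutral. Compound 3 is expected to give 75%, in a range from 55% to 92%. This estimate means a step of a number 3.5 percentage points lower from compound 2 to compound 3 (within the scatter), expected to lie within the scatter.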

Compound 3, a percentage reported as inhibition, at one concentration (the size of the read-out at that concentration, not a potency): 35.8%
Compound 3: the middle estimate sits 39.2 percentage points above what was measured; the measured number lies below the stated range.
By their numbers in this assay, from the lowest: compound 3; then compound 2; then compound 1.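

In this assay, a group of 7 heavy atoms (5 carbon, 1 nitrogen, 1 sulfur; no ring) in place of a group of 3 heavy atoms (1 carbon, 1 nitrogen, 1 sulfur; no ring) gives a number 42.7 percentage points lower from compound 2 to compound 3 (beyond the scatter). The chain carrying the isothiocyanate is therefore a sensitive place in this series, and this step is larger than the fluoro step, a number 12.7 percentage points lower from compound 1 to compound 2 (beyond the scatter). No measurement here bears on what lies behind the chain step.

With only two chain lengths shown, both on the fluoro compounds, the shape of the dependence on length remains open, as does the size of the step without the fluoro substituent. Also open, from the compounds shown here alone, is how an intermediate or still longer chain would read, or a chain ending in an amine in place of the isothiocyanate.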